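Carboxy in place of hydrogen: expected step

The compounds below may be only part of what the source reports. "The series", "measured", "known", "first", "only" and "open" are said of these compounds alone.

Compound 1 `Cc1n[nH]c2c1C(c1ccc(N(C)C)cc1)C(C(=O)NNC(N)=S)=C(N)N2`: 5210 nM
Compound 2 `Cc1n[nH]c2c1C(c1ccc(N(C)C)cc1)C(C(=O)N/N=C/c1ccc(Cl)cc1)=C(N)N2`: 25200 nM
Compound 3 `Cc1n[nH]c2c1C(c1ccc(N(C)C)cc1)C=C(N)N2`: 11200 nM

All three values come from a functional assay on MCF7 cells (Homo sapiens) for cytotoxicity, read by MTT assay, with a stated time of 48 h; on this read-out higher numbers stand for weaker inhibition and lower numbers for stronger inhibition. Compound 3 , with hydrogen on the double-bonded ring carbon, stands second highest of the three numbers, with compound 1 lower and compound 2 higher.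

The next compound is compound 4 `Cc1n[nH]c2c1C(c1ccc(N(C)C)cc1)C(C(=O)O)=C(N)N2`, which has carboxy in place of hydrogen on a double-bonded ring carbon.

Among the measured compounds shown here, two measured steps bear on this change. Hydrogen in place of the side group of compound 1 on that same carbon gives a 2.1-fold higher number from compound 1 to compound 3 (0.33 log units; beyond the scatter). Changing the end of that side group gives a 4.8-fold higher number from compound 1 to compound 2 (0.68 log units; beyond the scatter). Both steps are modest. The three compounds show no single direction, since the side group of compound 1 goes with a lower number than hydrogen and the side group of compound 2 goes with a higher one. Carboxy matches neither group, and no measured compound carries it. In this assay a modest step is therefore expected, with no firm direction and only a slight lean towards a higher number.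

The expected step is a 1.2-fold higher number from compound 3 to compound 4 (0.06 log units; within the scatter). Compound 4 is estimated at 13000 nM, with an expected range of 5000 nM to 32000 nM.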

Compound 4, half-maximal inhibitory concentration: 22000 nM
Beside the measured number, compound 4's estimate is 1.7-fold (0.23 log units) below it; the measured number falls inside the stated range.
By their numbers in this assay, from the lowest: compound 1; then compounds 3, 4 and 2 (each within the scatter of the next, the first and the last beyond it).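

In this assay, carboxy on the double-bonded ring carbon cannot be told apart from hydrogen, with a 2.0-fold higher number from compound 3 to compound 4 (0.29 log units; within the scatter). It also cannot be told apart from the side group of compound 2, with a 1.1-fold lower number from compound 2 to compound 4 (0.06 log units; within the scatter), so one oxygen atom and that larger group of 10 heavy atoms on the carbonyl carbon read alike here. Only the side group of compound 1 stands apart, with a 4.2-fold higher number from compound 1 to compound 4 (0.63 log units; beyond the scatter), which makes that side group on the carbonyl carbon, and not the carbonyl itself, the feature that goes with the lowest number among these four compounds. No evidence is at hand on the reason for these numbers.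

Open, as far as these compounds go, is whether the lower number of compound 1 depends on its sulfur or on its chain, a question that a primary amide, a methyl ester or the oxygen counterpart of that side group on the same carbonyl carbon would bear on. From the compounds shown here alone, the group of 9 heavy atoms is the same in all four compounds, so whether a methoxy or a fluorine on it in place of the dimethylamino group would change these numbers also stays open.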